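The source may hold more compounds than are shown below. What is called first, only, known or untested is meant among the compounds shown, and "the series" means these compounds.

Working notes on the series.

In an assay for inhibition of protein disulfide-isomerase (Homo sapiens), with a stated time of 1 h (on this read-out higher numbers stand for weaker inhibition and lower numbers for stronger inhibition), compound 1, `Oc1c(C(Nc2ccccn2)c2ccccc2Cl)ccc2cccnc12`, gives 500 nM. Two further compounds were measured in this assay. Compound 2, `Oc1cc(F)ccc1C(c1ccc2ccoc2c1O)N1CCCCC1`, gives 1070 nM, and compound 3, `Oc1c(C(c2ccc(F)cc2)N2CCCCC2)ccc2scnc12`, gives 570 nM. On these numbers compound 1 stands at the lower end of the set: its number and that of compound 3 lie within the scatter of each other, so no order between them can be read, while the gap from compound 1 to compound 2 lies beyond the scatter. Among the measured compounds shown here, none of the three compounds differs from another in a single place, so no step within the measured set can be counted.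

Compound 4, `Oc1cccc(C(Nc2ccccn2)c2ccc3cccnc3c2O)c1Cl`, differs from compound 1 in one place: hydroxy in place of hydrogen on an aromatic carbon. In words, a hydroxy takes the place of a hydrogen on an aromatic carbon, ortho to a chloro group and meta to a large group; cut one bond further out, the change reads as 2-chlorophenyl to 2-chloro-3-hydroxyphenyl. For the measured compounds named here, no measured pair in the set shows what such a change does on this assay, so the expectation rests on the number of compound 1 alone. The step from compound 1 to compound 4 in this assay is estimated as a 1.3-fold lower number from compound 1 to compound 4 (0.10 log units; within the scatter), a change not clearly beyond the scatter in either direction. For compound 4 the estimate in this assay is 400 nM, with a range of 150 nM to 1200 nM.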

Compound 4, half-maximal inhibitory concentration: 370 nM
For compound 4 the middle estimate is 1.1-fold (0.03 log units) above the measured one; the measured number falls inside the stated range.
By their numbers in this assay, from the lowest: compounds 4, 1, 3 and 2 (each within the scatter of the next, the first and the last beyond it).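

In this assay the series gains its first single-place step, a 1.4-fold lower number from compound 1 to compound 4 (0.13 log units; within the scatter) on going from hydrogen to hydroxy on an aromatic carbon, ortho to a chloro group and meta to a large group. This place on the core of compound 1 therefore accepts a hydroxy with no change that can be told from the scatter, and 2-chlorophenyl and 2-chloro-3-hydroxyphenyl cannot be put in order on this read-out. Nothing at hand bears on why the number holds at this position.

On these data alone, whether a methoxy, an amine or a carboxylic acid at the same place would move the number beyond the scatter remains open. Also open, as far as these compounds go, are whether the hydroxy gives a like step on the cores of compound 2 and compound 3, and whether the step depends on the chloro group.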